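Replacing the imidazolyl on the amide nitrogen with hydroxy

A few compounds are considered here, and "the series" means these few. Any claim that something is new, unique, unknown or untested is made for them only; others in the source may bear on it.

Compound 2 `Cc1ccc(OCC(=O)N(Cc2cccs2)c2nccn2C)cc1`: 1790 nM
Compound 1 `Cc1ccc(OCC(=O)N(Cc2cccs2)c2ccn(C)n2)cc1`: 855 nM

In an assay on HEK293 cells for agonist activity at transient receptor potential cation channel subfamily M member 8 (Homo sapiens), read by fluorescence and calcium flux, with a stated time of 15 min (on this read-out higher numbers stand for an effect only at larger amounts of compound and lower numbers for an effect already at smaller amounts), compound 2 gives the highest number of the two, and the nearest is compound 1 with 855 nM. Among the measured compounds shown here, the one step seen, a 2.1-fold higher number from compound 1 to compound 2 (0.32 log units; beyond the scatter), exchanged one five-membered heteroaryl for another and stayed modest. Compound 3 `Cc1ccc(OCC(=O)N(O)Cc2cccs2)cc1` goes further: hydroxy in place of 1-methyl-1H-imidazol-2-yl on an amide-type nitrogen. For the measured compounds named here, no measured step removes the whole ring from this nitrogen, so the earlier step gives only a weak lead. A loss larger than that step is expected, a 3.4-fold higher number from compound 2 to compound 3 (0.53 log units; beyond the scatter), and compound 3 is estimated at 6000 nM, within 1500 nM to 30000 nM.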

Compound 3, half-maximal effective concentration: 8000 nM
For compound 3 the middle estimate is 1.3-fold (0.12 log units) below the measured one; measured number inside the range.
By their numbers in this assay, from the lowest: compound 1; then compound 2; then compound 3.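

In this assay, taking the whole ring off the amide-type nitrogen costs more than exchanging one ring for the other: hydroxy gives a 4.5-fold higher number from compound 2 to compound 3 (0.65 log units; beyond the scatter) and a 9.4-fold higher number from compound 1 to compound 3 (0.97 log units; beyond the scatter). Even so, the ring is not needed for a measurable effect, since compound 3 still gives a number with only hydroxy on this nitrogen. On these data alone, whether a methoxy group, a methyl group or an amine on this nitrogen would fall closer to the ring-bearing compounds stays open. No outside evidence bears on the reason for this loss.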